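Trading a Hydroxymethyl Piperidine for a Methoxy Piperidine

This account rests on a few compounds, and the source may have more. Where it says the series, first, only, none or still open, it means among the compounds named here.

Of the compounds shown here, two have been measured so far. For the measured compounds named here, compound 1 `Cc1ccc(N2CCC(C)(O)CC2)nc1C(=O)Nc1c(C)ccc(C(=O)O)c1C` and compound 2 `Cc1ccc(N2CCCC(CO)C2)nc1C(=O)Nc1c(C)cc(C(=O)O)cc1C` differ from each other in more than one place, so no single step connects them and their numbers can only be set side by side. In a functional assay on HEK293 cells for antagonist activity at prostaglandin E2 receptor EP4 subtype (Homo sapiens), read by HTRF and cAMP accumulation, with a stated time of 20 min (a higher number here means a weaker inhibitor, a lower number a stronger inhibitor), compound 1 gives 87.9 nM, while compound 2 gives 16.5 nM, the lower of the two numbers and a gap that lies beyond the usual scatter. Compound 3 `COC1CCN(c2ccc(C)c(C(=O)Nc3c(C)cc(C(=O)O)cc3C)n2)CC1` has not yet been measured. It differs from compound 2 in one place: 4-methoxypiperidin-1-yl in place of 3-(hydroxymethyl)piperidin-1-yl on an aromatic carbon. The group that leaves has a hydrogen-bond donor, the group that enters has none. Going by the values given here, no measured pair shows what such a change does here, so the expectation rests on compound 2 alone and on the fact that the rest of the molecule is unchanged. The step that this estimate means, a 1.5-fold higher number from compound 2 to compound 3 (0.18 log units; within the scatter), is expected to be modest and to run toward a somewhat weaker inhibitor, though it may not exceed the scatter. In this assay compound 3 is estimated at 25 nM, with a likely range from 8 nM to 80 nM.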

Compound 3, half-maximal inhibitory concentration: 96.7 nM
Beside the measured number, compound 3's estimate is 3.9-fold (0.59 log units) below it; the whole stated range lies below it.
By their numbers in this assay, from the lowest: compound 2; then compounds 1 and 3 (each within the scatter of the next).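

In this assay, putting 4-methoxypiperidin-1-yl in place of 3-(hydroxymethyl)piperidin-1-yl gives a 5.9-fold higher number from compound 2 to compound 3 (0.77 log units; beyond the scatter) and shows that this aromatic carbon, next to the ring nitrogen, does not accept every piperidine equally. The two groups match in heavy atoms, ring size and hydrogen-bond acceptor count, so even a rearrangement of the same atoms is enough to move the number beyond the scatter; the group that leaves has a hydrogen-bond donor and the group that enters has none, and the oxygen-bearing substituent also sits at a different place on the piperidine. No measurement available here says which of these differences matters or why the number moves.

The compounds shown leave those two differences tied together, with no way yet to weigh the donor against the placement of the substituent. A pair such as 4-(hydroxymethyl)piperidin-1-yl and 3-methoxypiperidin-1-yl on the same core would pull them apart, since the first keeps the hydroxyl with the substitution pattern of compound 3 and the second drops it with the pattern of compound 2.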